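Positional methoxy isomers on the benzylamine of a bis(trifluoromethyl)sulfonamide series

This account rests on a few compounds, and the source may have more. Where it says the series, first, only, none or still open, it means among the compounds named here.

Measured compounds:
compound 1, `O=S(=O)(NCCCNCc1ccc(C(F)(F)F)cc1)c1cc(C(F)(F)F)cc(C(F)(F)F)c1`, 2000 nM
compound 2, `COc1ccc(CNCCCNS(=O)(=O)c2cc(C(F)(F)F)cc(C(F)(F)F)c2)cc1`, 2400 nM

Both numbers come from a functional assay on Capan-2 cells (Homo sapiens) for inhibition, read by MTT assay, with a stated time of 72 h; on this read-out lower numbers stand for stronger inhibition of growth and higher numbers for weaker inhibition of growth. Compound 2 gives 2400 nM and compound 1 gives 2000 nM; the two sit within the scatter of each other, so compound 2 stands apart from nothing on the numbers shown. Among the compounds with values here, the only measured step, a 1.2-fold higher number from compound 1 to compound 2 (0.08 log units; within the scatter), concerns the group on the benzylic ring, and it is within the scatter.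

Compound 3, `COc1cccc(CNCCCNS(=O)(=O)c2cc(C(F)(F)F)cc(C(F)(F)F)c2)c1`, keeps the same atoms joined differently: 3-methoxyphenyl in place of 4-methoxyphenyl on a saturated chain carbon bound to an amine nitrogen. Within the data shown here, no measured step tests a move of the methoxy group around that ring. Among the measured compounds shown here, what is known is only that swapping the group on that ring, as in a 1.2-fold higher number from compound 1 to compound 2 (0.08 log units; within the scatter), left this assay essentially unchanged. A small step in this assay is therefore expected, in no clear direction, and not beyond the scatter.

Compound 3 is expected to give about 2400 nM, within 1100 nM to 5000 nM, which is an estimated step of no change at the digits printed from compound 2 to compound 3 (within the scatter).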

Compound 3, concentration for 50% growth inhibition: 6400 nM
Compound 3: middle estimate off by 2.7-fold (0.43 log units), on the low side; the measured number lies above the stated range.
By their numbers in this assay, from the lowest: compounds 1 and 2 (each within the scatter of the next); then compound 3.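

Working notes on the benzylamine ring. In this assay, the placement of the methoxy group has a measurable effect: 3-methoxyphenyl in place of 4-methoxyphenyl gives a 2.7-fold higher number from compound 2 to compound 3 (0.43 log units; beyond the scatter), whereas the exchange of trifluoromethyl for methoxy in the earlier pair stayed within the scatter, at a 1.2-fold higher number from compound 1 to compound 2 (0.08 log units; within the scatter). Compound 3 also stands apart from the 4-(trifluoromethyl)phenyl compound, with a 3.2-fold higher number from compound 1 to compound 3 (0.51 log units; beyond the scatter), which makes it the weakest of the three on this read-out, although both steps are modest and this reading rests on a single isomer pair. Nothing shown here offers an explanation for the difference between the 4-methoxyphenyl and 3-methoxyphenyl compounds.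

On these data alone, it remains open whether this weakening belongs to the methoxy group alone or would recur with another group, such as 3-(trifluoromethyl)phenyl or 3-hydroxyphenyl, set against the matching compounds. Also open, as far as these compounds go, is whether the same isomer step would hold on a longer chain in place of the present one, or with a carboxylic acid on the benzylamine ring.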